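Ring-bearing aryl substituents in a TRPV1 antagonist series

The source may report more compounds than this note shows. Statements on the series, on what has been measured and on what is new or still open speak of the compounds shown alone.

Measured compounds:
compound 1 `CC(C(=O)NCc1ccc(C(F)(F)F)cc1N1CCCC1)c1ccc(NS(C)(=O)=O)c(F)c1`: 2.3 nM
compound 2 `CC(C(=O)NCc1ccc(C(F)(F)F)cc1N1CCN(C2CCCCC2)CC1)c1ccc(NS(C)(=O)=O)c(F)c1`: 13.8 nM
compound 3 `CC(C(=O)NCc1ccc(C(F)(F)F)cc1SC1CCCC1)c1ccc(NS(C)(=O)=O)c(F)c1`: 0.3 nM

Compound 3 gives the lowest number in an assay on CHO cells for antagonist activity at transient receptor potential cation channel subfamily V member 1 (Homo sapiens), read by FLIPR; a higher number here means a weaker inhibitor, a lower number a stronger inhibitor; its nearest neighbour is compound 1, a 7.7-fold lower number from compound 1 to compound 3 (0.88 log units; beyond the scatter), while compound 2 lies furthest, a 46-fold lower number from compound 2 to compound 3 (1.66 log units; beyond the scatter). Compound 4 `CCCCCc1cc(C(F)(F)F)ccc1CNC(=O)C(C)c1ccc(NS(C)(=O)=O)c(F)c1` differs from compound 3 in one place: pentyl in place of cyclopentylsulfanyl on an aromatic carbon. Within the data shown here, neither measured step covers a chain in place of a ring, and the only step into the cyclopentylsulfanyl group, a 7.7-fold lower number from compound 1 to compound 3 (0.88 log units; beyond the scatter), starts from a ring-bearing group, so the measured steps bear only indirectly on this change. A modest move to a higher number, or none beyond the scatter, is expected, a 3.3-fold higher number from compound 3 to compound 4 (0.52 log units; beyond the scatter). Compound 4 is estimated at 1 nM in this assay, within 0.3 nM to 4 nM.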

Compound 4, inhibition constant: 0.4 nM
Beside the measured number, compound 4's estimate is 2.5-fold (0.40 log units) above it; measured number inside the range.
By their numbers in this assay, from the lowest: compounds 3 and 4 (each within the scatter of the next); then compound 1; then compound 2.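

At this aromatic carbon, in this assay, an open chain serves as well as a sulfur-linked ring: replacing cyclopentylsulfanyl with pentyl gives a 1.3-fold higher number from compound 3 to compound 4 (0.12 log units; within the scatter). Pentyl also gives a clear gain over both nitrogen-linked ring groups, pyrrolidin-1-yl with a 5.8-fold lower number from compound 1 to compound 4 (0.76 log units; beyond the scatter) and 4-cyclohexylpiperazin-1-yl with a 35-fold lower number from compound 2 to compound 4 (1.54 log units; beyond the scatter). No measurement available here explains these differences.

The ring and the sulfur leave together, so a cyclopentyl or pentylsulfanyl group would be needed to separate them. As far as these compounds go, a shorter propyl chain, or a pentyl chain ending in an amine or a carboxylic acid, remains open at this position.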